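This account rests on a few compounds, and the source may have more. Where it says the series, first, only, none or still open, it means among the compounds named here.

Compound 1 `COc1cc(/C=C/C(=O)c2cccc(-n3cc(-c4ccc(Cl)cc4)[nH]c3=O)c2)cc(OC)c1OC` gives 10900 nM in a functional assay on SK-MEL-28 cells (Homo sapiens) for inhibition; a higher number here means a weaker inhibitor of growth, a lower number a stronger inhibitor of growth.
Compound 2 `COc1cc(/C=C/C(=O)c2cccc(-n3cc(-c4ccccc4)[nH]c3=O)c2)cc(OC)c1OC` gives 1740 nM in this assay.
Compound 3 `COc1ccc(-c2cn(-c3cccc(C(=O)/C=C/c4cc(OC)c(OC)c(OC)c4)c3)c(=O)[nH]2)cc1` gives 2030 nM in this assay.

Compound 3 stands second highest of the three numbers in this assay. Its nearest neighbour is compound 2, from which it is separated by a 1.2-fold higher number from compound 2 to compound 3 (0.07 log units; within the scatter), and its furthest is compound 1, from which it is separated by a 5.4-fold lower number from compound 1 to compound 3 (0.73 log units; beyond the scatter).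

Compound 4 `COc1cc(/C=C/C(=O)c2cccc(-n3cc(-c4cc(OC)c(OC)c(OC)c4)[nH]c3=O)c2)cc(OC)c1OC` differs from compound 3 by 3,4,5-trimethoxyphenyl in place of 4-methoxyphenyl on an aromatic carbon. Among the compounds with values here, no measured step adds methoxy groups to a ring that already carries one. The steps that come nearest all concern substitution on this same aromatic carbon: a 6.3-fold lower number from compound 1 to compound 2 (0.80 log units; beyond the scatter) and a 5.4-fold lower number from compound 1 to compound 3 (0.73 log units; beyond the scatter) were both modest, while a 1.2-fold higher number from compound 2 to compound 3 (0.07 log units; within the scatter) lay within the scatter. Since the exchange of hydrogen for methoxy here changed the number little, the two further methoxy groups are expected to shift it at most modestly. Compound 4 is therefore estimated at 2600 nM, within a range of 900 nM to 7500 nM. The expected step is a 1.3-fold higher number from compound 3 to compound 4 (0.11 log units; within the scatter).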

Compound 4, concentration for 50% growth inhibition: 1610 nM
Estimate against measurement, compound 4: 1.6-fold (0.21 log units) above; low and high end bracket the measured number.
By their numbers in this assay, from the lowest: compounds 4, 2 and 3 (each within the scatter of the next); then compound 1.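

In this assay, adding two further methoxy groups leaves the number within the scatter, with a 1.3-fold lower number from compound 3 to compound 4 (0.10 log units; within the scatter), and replacing phenyl with 3,4,5-trimethoxyphenyl does the same, with a 1.1-fold lower number from compound 2 to compound 4 (0.03 log units; within the scatter). Phenyl, 4-methoxyphenyl and 3,4,5-trimethoxyphenyl therefore cannot be told apart at this position, and only the 4-chlorophenyl of compound 1 stands apart, as a 6.8-fold lower number from compound 1 to compound 4 (0.83 log units; beyond the scatter) shows. Nothing given here accounts for this flat response or for the separate place of the chloro compound.

The compounds shown leave open whether the chloro result belongs to that atom alone or would recur with fluoro or bromo on the same ring. They also leave open whether a ring carrying an amine or a carboxylic acid would stay level with the methoxy compounds.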